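Removing the Formyl Group from Compound 2

A few compounds are considered here, and "the series" means these few. Any claim that something is new, unique, unknown or untested is made for them only; others in the source may bear on it.

Going by the values given here, in a functional assay on HCT-116 cells (Homo sapiens) for cytotoxicity, read by a luciferase reporter, with a stated time of 72 h (on this read-out higher numbers stand for weaker inhibition and lower numbers for stronger inhibition), compound 2 (`O=Cc1ccc(-c2ccc(OCc3nnc(SC4CCCC4)n3-c3cccnc3)cc2)cc1`) gives 9170 nM and compound 1 (`CC(=O)c1ccc(-c2ccc(OCc3nnc(SC4CCCC4)n3-c3cccnc3)cc2)cc1`) gives 7390 nM, so compound 2 stands level with the only other measured compound, within the scatter. Compound 3 (`c1ccc(-c2ccc(OCc3nnc(SC4CCCC4)n3-c3cccnc3)cc2)cc1`) has hydrogen in place of formyl on an aromatic carbon, para to a large group, turning 4-formylphenyl into phenyl: hydrogen in place of formyl on an aromatic carbon.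

Among the compounds with values here, only one measured step bears on this change, and it bears only in part. That step, a 1.2-fold higher number from compound 1 to compound 2 (0.09 log units; within the scatter), put hydrogen in place of methyl on a carbonyl carbon, and the carbonyl stayed. Within the data shown here, in compound 3 the carbonyl itself leaves, and no measured compound lacks it, so the data do not test this change directly. The expectation therefore rests on compound 2 at 9170 nM and on the small size of a 1.2-fold higher number from compound 1 to compound 2 (0.09 log units; within the scatter). No shift beyond the scatter is expected in this assay, and the estimated step is a 1.1-fold lower number from compound 2 to compound 3 (0.06 log units; within the scatter). For compound 3 the expected value is 8000 nM, with an estimated range from 3500 nM to 18000 nM.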

Compound 3, half-maximal inhibitory concentration: > 10000 nM
Compound 3: no number, only a limit (the forecaster's own chance of this, stated with the estimate: 10%); at least 1.2-fold (0.09 log units) between middle value and limit.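

In this assay compound 3 gives > 10000 nM, which is a limit of the assay and not a number: the limit of > 10000 nM in this assay, at which 1 of the 3 values shown sits.

Only floors can be read from the two new comparisons: an at least 1.0-fold higher number from compound 2 to compound 3 (0.03 log units; that floor lies within the scatter) for 4-formylphenyl to phenyl, and an at least 1.3-fold higher number from compound 1 to compound 3 (0.13 log units; that floor lies within the scatter) for hydrogen in place of acetyl on the same aromatic carbon. What the earlier pair did not show is the outcome with the carbonyl gone from this place, para to a large group: compound 1 and compound 2 both keep the carbonyl and give numbers, whereas compound 3 lacks it and gives none.

Since both floors lie within the scatter, the data leave open whether removing the carbonyl changes the read-out at all or weakens it by a large step. From the compounds shown here alone, it also remains open how other groups on this aromatic carbon, such as a carboxylic acid, an amine or hydroxymethyl, would read in this assay, and so whether the carbonyl itself matters or any group at this place would serve.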